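Cytotoxicity notes: methoxy to trifluoromethyl on compound 2

A few compounds are considered here, and "the series" means these few. Any claim that something is new, unique, unknown or untested is made for them only; others in the source may bear on it.

Values in an ADME assay on HepG2 2.2.15 cells (Homo sapiens) for cytotoxicity, read by CCK-8 assay, with a stated time of 8 days (on this read-out lower numbers stand for higher toxicity in this test and higher numbers for lower toxicity in this test), are as follows
- compound 1 `COc1ccc(-c2cc(NC(=O)c3ccc(C)cc3O)c[nH]c2=O)cc1` gives 46100 nM
- compound 2 `COc1ccc(C(=O)Nc2c[nH]c(=O)c(-c3cccc(C)c3)c2)c(O)c1` gives > 100000 nM

Compound 2 gives no number, only the limit of > 100000 nM in this assay, at which 1 of the 2 values shown sits, and nothing more. Compound 3 `Cc1cccc(-c2cc(NC(=O)c3ccc(C(F)(F)F)cc3O)c[nH]c2=O)c1` carries trifluoromethyl in place of methoxy on an aromatic carbon, meta to a hydroxy group and para to a large group trifluoromethyl in place of methoxy on an aromatic carbon in comparison with compound 2. Within the data shown here, no measured pair shows this change. Among the measured compounds shown here, a moderate step toward lower numbers in this assay is expected, resting only on compound 1 at 46100 nM as the single measured number. The expected move is an at least 2.0-fold lower number from compound 2 to compound 3 (0.30 log units; that floor lies within the scatter) in this estimate. For compound 3 the estimated value is 50000 nM with an expected range from 15000 nM to 100000 nM in this read-out.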

Compound 3, half-maximal cytotoxic concentration: 24200 nM
Estimate against measurement, compound 3: 2.1-fold (0.32 log units) above; the measured number falls inside the stated range.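

In this assay, among these compounds, trifluoromethyl in place of methoxy on this aromatic carbon, meta to a hydroxy group and para to a large group, gives the first direct reading of a change at this position: an at least 4.1-fold lower number from compound 2 to compound 3 (0.61 log units; beyond the scatter). Even as a floor, this step lies beyond the scatter. Compound 2 stands at a limit and not at a number, so the step has no upper bound: the limit of > 100000 nM in this assay, at which 1 of the 3 values shown sits.

From the compounds shown here alone, how a chlorine atom, a nitrile or an amine on this carbon would read in this assay stays open. Going by these compounds, whether the same change gives a similar step on the core of compound 1 also stays open.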